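Ethoxy in place of cyano: expectation for compound 3

The compounds below may be only part of what the source reports. "The series", "measured", "known", "first", "only" and "open" are said of these compounds alone.

For the measured compounds named here, in an in vitro ADME assay on microsomes from liver (Simiiformes) (a lower number here means that the compound disappears faster, a higher number that the compound lasts longer), compound 1 `Cc1cc(CCCOc2c(C)cc(-c3noc(CC(F)(F)F)n3)cc2C)on1` gives 0.533 h and compound 2 `Cc1cc(CCCOc2c(C)cc(-c3noc(C#N)n3)cc2C)on1` gives 0.283 h as half-life, so compound 2 stands within the scatter of the only other number. Going by the values given here, compound 3 `CCOc1nc(-c2cc(C)c(OCCCc3cc(C)no3)c(C)c2)no1` comes from compound 2 by ethoxy in place of cyano on an aromatic carbon as its single change: ethoxy in place of cyano on an aromatic carbon, next to the ring nitrogen and next to the ring oxygen. Among the compounds with values here, one measured step bears on this carbon, namely a 1.9-fold lower number from compound 1 to compound 2 (0.27 log units; within the scatter) for cyano in place of 2,2,2-trifluoroethyl. Within the data shown here, no ethoxy example has been measured, so this guidance is thin and the range stays wide. In this assay the expected change is a 1.2-fold higher number from compound 2 to compound 3 (0.09 log units; within the scatter) and thus none beyond the scatter. The estimate for compound 3 is 0.35 h with an expected range from 0.15 h to 0.8 h for now.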

Compound 3, half-life: > 2.5 h
Compound 3: no number, only a limit (the forecaster's own chance of this, stated with the estimate: 2%); middle value at least 7.1-fold (0.85 log units) from the limit.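

In this assay, ethoxy at this carbon, next to the ring nitrogen and next to the ring oxygen, gives an at least 8.8-fold higher number from compound 2 to compound 3 (0.94 log units; beyond the scatter), and the same group gives an at least 4.6-fold higher number from compound 1 to compound 3 (0.67 log units; beyond the scatter). For the compounds shown here, until now the only step at this carbon lay within the scatter, whereas both steps to ethoxy lie beyond it, so the group at this position can clearly change the half-life. The result for compound 3 is a limit of the assay and not a number, so both steps give only a lower bound on the size of the change: the limit of > 2.5 h in this assay, at which 1 of the 3 values shown sits.

Going by these compounds, how far the true half-life of compound 3 lies past this limit remains open. Also open, on these data alone, is whether a methoxy, an ethyl, an amine or a longer alkoxy chain at this carbon would match ethoxy.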